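Cyclising the propargylic amino alcohol of compound 1

The compounds below may be only part of what the source reports. "The series", "measured", "known", "first", "only" and "open" are said of these compounds alone.

Among the compounds with values here, compound 1 `CN[C@@H](C#Cc1c(F)ccc2c1/C(=C/c1[nH]ccc1OC)C(=O)N2)CO` carries a 4-hydroxy-3-(methylamino)but-1-yn-1-yl arm on the shared core; in a functional assay on SW480 cells (Homo sapiens) for inhibition (a higher number here means a weaker inhibitor, a lower number a stronger inhibitor), compound 1 gives 80 nM, the lowest of the two numbers measured so far. Compound 2 `COc1cc[nH]c1/C=C1\C(=O)Nc2ccc(F)c(C#C[C@@H](N)[C@@H](C)O)c21` is its nearest neighbour, and in this assay compound 2 gives 210 nM; the step of a 2.6-fold higher number from compound 1 to compound 2 (0.42 log units; beyond the scatter) shows that reshaping the amino alcohol costs some potency.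

Compound 3 `COc1cc[nH]c1/C=C1\C(=O)Nc2ccc(F)c(C#C[C@@H]3C[C@H](O)CN3)c21` differs from compound 1 by 4-hydroxypyrrolidin-2-yl in place of 2-hydroxy-1-(methylamino)ethyl on a triple-bonded carbon. The 4-hydroxypyrrolidin-2-yl ring closes the 2-hydroxy-1-(methylamino)ethyl group into a five-membered ring with the same counts of donors and acceptors. Within the data shown here, only the step from compound 1 to compound 2 bears on this, and it was modest; a similar modest loss, or no change beyond the scatter, is the expected outcome, a 1.6-fold higher number from compound 1 to compound 3 (0.21 log units; within the scatter). For compound 3 the estimate in this assay is 130 nM, with a range from 45 nM to 400 nM.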

Compound 3, half-maximal inhibitory concentration: 90 nM
Compound 3: middle estimate off by 1.4-fold (0.16 log units), on the high side; the range from low to high includes it.
By their numbers in this assay, from the lowest: compounds 1 and 3 (each within the scatter of the next); then compound 2.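

In this assay, the triple-bonded carbon accepts the closed 4-hydroxypyrrolidin-2-yl ring in place of the open 2-hydroxy-1-(methylamino)ethyl group, with a 1.1-fold higher number from compound 1 to compound 3 (0.05 log units; within the scatter) as the step, so ring closure here carries no cost beyond the scatter. The potency lost with 1-amino-2-hydroxypropyl is therefore not shared by every reshaped amino alcohol: a 2.3-fold lower number from compound 2 to compound 3 (0.37 log units; beyond the scatter) is the step for exchanging that open group for the ring. No supporting measurement is available to explain these differences.

The compounds shown leave open whether the ring hydroxyl is needed, a question that a plain pyrrolidin-2-yl group would address. They also leave open how a piperidin-2-yl ring, or a methyl group on the ring nitrogen, would read in this assay at this position.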